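Notes on a sulfur-for-oxygen change at compound 2

A few compounds are considered here, and "the series" means these few. Any claim that something is new, unique, unknown or untested is made for them only; others in the source may bear on it.

In an ADME assay on Vero cells (Chlorocebus sabaeus) for cytotoxicity, read by MTT assay, with a stated time of 96 h (on this read-out higher numbers stand for lower toxicity in this test and lower numbers for higher toxicity in this test), compound 1 `COc1ccc(-c2nc3cc(/C(C)=N/O)ccc3[nH]2)c(OC)c1` reports only a limit, > 100000 nM. Going by the values given here, compound 2 `COc1ccc(-c2nc3cc(/C(C)=N/NC(N)=O)ccc3[nH]2)c(OC)c1` gives 80000 nM, the only actual number so far. Compound 3 `COc1ccc(-c2nc3cc(/C(C)=N/NC(N)=S)ccc3[nH]2)c(OC)c1` loses the carbamoyl on an amine nitrogen: a group of 3 heavy atoms (1 carbon, 1 nitrogen, 1 sulfur; no ring) in place of a group of 3 heavy atoms (1 carbon, 1 nitrogen, 1 oxygen; no ring), on an amine nitrogen. Among the compounds with values here, the single measured step, an at least 1.2-fold lower number from compound 1 to compound 2 (0.09 log units; that floor lies within the scatter), is the only guide and offers no sizeable precedent. A modest move toward a lower number is therefore expected, with a 2.0-fold lower number from compound 2 to compound 3 (0.30 log units; within the scatter) as the estimated step. Compound 3 is estimated at 40000 nM, with an expected range of 10000 nM to 100000 nM.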

Compound 3, half-maximal cytotoxic concentration: > 100000 nM
Compound 3 gave a limit, no number; the forecaster's own chance of this, stated with the estimate: 15%; middle value at least 2.5-fold (0.39 log units) away from the limit.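

Putting sulfur in place of oxygen on this amine nitrogen gives an at least 1.2-fold higher number from compound 2 to compound 3 (0.09 log units; that floor lies within the scatter) in this assay. The readable part of this change therefore stays within the scatter, and the two groups are not separated. The step from compound 1 to compound 3 cannot be read, and limits dominate the series: the limit of > 100000 nM in this assay, at which 2 of the 3 values shown sit.

On these data alone, whether any group on this amine nitrogen gives a number clearly lower than that of compound 2 stays open. Also open, as far as these compounds go, is how an acetyl group or a longer chain in place of the carbamoyl would read in this assay.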